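A few compounds are considered here, and "the series" means these few. Any claim that something is new, unique, unknown or untested is made for them only; others in the source may bear on it.

In a functional assay on V79 cells (Cricetulus griseus) for cytotoxicity, read by colony formation (a lower number here means a stronger inhibitor, a higher number a weaker inhibitor), compound 3 `NC1CCCN(c2cc3c(cc2F)c(=O)c(C(=O)O)cn3C2CC2)C1` gives > 500 ug/mL, which is a limit and not a number. Compound 4 `NC1CCCN(c2c(F)cc3c(=O)c(C(=O)O)cn(C4CC4)c3c2C(F)(F)F)C1` differs from it by a single change: trifluoromethyl in place of hydrogen on an aromatic carbon. For the measured compounds named here, no measured pair tests this change directly, so the nearest evidence comes from two compounds that already carry trifluoromethyl. Compound 1 `CCNCC1CCN(c2c(F)cc3c(=O)c(C(=O)O)cn(C4CC4)c3c2C(F)(F)F)C1` gives 120 ug/mL, and compound 2 `O=C(O)c1cn(C2CC2)c2c(C(F)(F)F)c(N3CCNCC3)c(F)cc2c1=O` gives 1650 ug/mL. The step between them, a 14-fold higher number from compound 1 to compound 2 (1.14 log units; beyond the scatter), is large and beyond the scatter, and it comes with piperazin-1-yl in place of 3-((ethylamino)methyl)pyrrolidin-1-yl. With trifluoromethyl present in both, the amine group alone therefore moves the number widely, so these two compounds fix neither the size nor the direction of the coming step with any confidence. A moderately lower number is nevertheless expected, with compound 1 at 120 ug/mL as the main pointer and compound 2 at 1650 ug/mL as the warning against it. The estimated change is an at least 1.6-fold lower number from compound 3 to compound 4 (0.22 log units; that floor lies within the scatter), and it is uncertain. For compound 4 the estimate is 300 ug/mL, with an expected range of 80 ug/mL to 1200 ug/mL.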

Compound 4, half-maximal inhibitory concentration: > 500 ug/mL
Compound 4: no number, only a limit; the forecaster's own chance of this, stated with the estimate: 15%; middle value at least 1.6-fold (0.22 log units) away from the limit.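

In this assay compound 4 gives > 500 ug/mL, which is a limit and not a number. With trifluoromethyl present in both, 3-aminopiperidin-1-yl in place of 3-((ethylamino)methyl)pyrrolidin-1-yl gives an at least 4.1-fold higher number from compound 1 to compound 4 (0.61 log units; beyond the scatter), so a second amine group, after piperazin-1-yl, sits on the higher side of compound 1, and that step lies beyond the scatter. The steps to compound 4 from compound 3 and from compound 2 cannot be read, because they rest on limits: the limit of > 500 ug/mL in this assay, at which 2 of the 4 values shown sit.

Going by these compounds, what trifluoromethyl in place of hydrogen does to the number on this aromatic carbon therefore stays open, as does the order of compound 2 and compound 4. Also open, on these data alone, is how a methyl group or a chlorine atom on that carbon, or an ethylamino group on the piperidine, would read here.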